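Swapping the Aryl Ketone Group: Compound 2 to Compound 4

A few compounds are considered here, and "the series" means these few. Any claim that something is new, unique, unknown or untested is made for them only; others in the source may bear on it.

Of the compounds shown here, three sharing one core have been measured in a functional assay on COLO 205 cells (Homo sapiens) for inhibition, read by sulforhodamine B assay, with a stated time of 48 h; on this read-out lower numbers stand for stronger inhibition of growth and higher numbers for weaker inhibition of growth. Compound 1 `COc1cc(-c2cc(/C=C/C(=O)c3ccc(N)cc3)[nH]n2)cc(OC)c1OC` gives 1740 nM, compound 2 `COc1cc(-c2cc(/C=C/C(=O)c3ccc(Cl)c(Cl)c3)[nH]n2)cc(OC)c1OC` gives 1260 nM, and compound 3 `COc1ccc(-c2cc(/C=C/C(=O)c3cc(OC)c(OC)c(OC)c3)[nH]n2)cc1OC` gives 1750 nM. Compound 2 has the lowest of the three numbers, yet both other values lie within the scatter of it. The next compound, compound 4 `COc1ccc(C(=O)/C=C/c2cc(-c3cc(OC)c(OC)c(OC)c3)n[nH]2)cc1`, differs from compound 2 in one place: 4-methoxyphenyl in place of 3,4-dichlorophenyl on a carbonyl carbon. Within the data shown here, the only single-point step so far, a 1.4-fold lower number from compound 1 to compound 2 (0.14 log units; within the scatter), changed the group on the same carbonyl carbon and stayed within the scatter, and compound 3 likewise sits within the scatter of compound 2. No step beyond the scatter is therefore expected, giving an estimated 1.2-fold higher number from compound 2 to compound 4 (0.08 log units; within the scatter). The expected value for compound 4 is 1500 nM, with a range from 700 nM to 3200 nM.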

Compound 4, concentration for 50% growth inhibition: 1730 nM
Compound 4: middle estimate off by 1.2-fold (0.06 log units), on the low side; the measured number falls inside the stated range.
By their numbers in this assay, from the lowest: compounds 2, 4, 1 and 3 (each within the scatter of the next).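

Replacing 3,4-dichlorophenyl with 4-methoxyphenyl on the carbonyl carbon gives a 1.4-fold higher number from compound 2 to compound 4 (0.14 log units; within the scatter), even though the entering group carries a hydrogen-bond acceptor and the leaving group carries none. Methoxy in place of amino on an aromatic carbon gives a 1.0-fold lower number from compound 1 to compound 4 (0.00 log units; within the scatter). Compounds 1, 2 and 4 therefore show three aryl groups at this place that this read-out cannot separate. On these data alone, whether a carboxylic acid or a longer chain at this place would give a step beyond the scatter stays open. No available evidence explains why these three groups read alike.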